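Acylthiosemicarbazides: 4-chlorophenyl in place of phenoxymethyl

A few compounds are considered here, and "the series" means these few. Any claim that something is new, unique, unknown or untested is made for them only; others in the source may bear on it.

Compound 1 `O=C(COc1ccccc1)NNC(=S)NCc1ccc(-c2ccccc2)cc1` gives the highest of the two numbers in an assay on isolated protein for inhibition of A disintegrin and metalloproteinase with thrombospondin motifs 5 (Homo sapiens), read by spectrophotometry, with stated times of 10 min and 3 h (a higher number here means a weaker inhibitor, a lower number a stronger inhibitor), at 10000 nM; its nearest neighbour is compound 2 `O=C(COc1cccc(Cl)c1)NNC(=S)NCc1ccc(-c2ccccc2)cc1`, which in this assay gives 2100 nM. For the measured compounds named here, the only measured step, a 4.8-fold lower number from compound 1 to compound 2 (0.68 log units; beyond the scatter), accompanies chloro in place of hydrogen on an aromatic carbon. Compound 3 `O=C(NNC(=S)NCc1ccc(-c2ccccc2)cc1)c1ccc(Cl)cc1` differs from compound 1 by 4-chlorophenyl in place of phenoxymethyl on a carbonyl carbon. Going by the values given here, the chloro part of that change is covered by the step from compound 1 to compound 2; the departure of the phenoxymethyl is covered by no measured pair. A modest lowering is therefore expected, a 3.3-fold lower number from compound 1 to compound 3 (0.52 log units; beyond the scatter), with added uncertainty. Compound 3 is estimated at 3000 nM, within 700 nM to 13000 nM.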

Compound 3, half-maximal inhibitory concentration: 700 nM
Compound 3: the middle estimate sits 4.3-fold (0.63 log units) above what was measured; measured number inside the range.
By their numbers in this assay, from the lowest: compound 3; then compound 2; then compound 1.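

On the carbonyl carbon, 4-chlorophenyl in place of phenoxymethyl gives a 14-fold lower number from compound 1 to compound 3 (1.15 log units; beyond the scatter), making compound 3 the strongest inhibitor of the three. With chloro present on both sides, 4-chlorophenyl in place of (3-chlorophenoxy)methyl still gives a 3.0-fold lower number from compound 2 to compound 3 (0.48 log units; beyond the scatter), so the gain at this position does not rest on the presence of chloro alone. No supporting data on the origin of these steps are available.

The shares of the chloro and of the departing phenoxymethyl remain unseparated; a plain phenyl on the carbonyl carbon would divide them. As far as these compounds go, how a carboxylic acid or an amine in place of the chloro would read also remains open.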